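This account rests on a few compounds, and the source may have more. Where it says the series, first, only, none or still open, it means among the compounds named here.

Values in a functional assay on Jurkat cells (Homo sapiens) for inhibition, read by CCK-8 assay, with a stated time of 48 h; on this read-out higher numbers stand for weaker inhibition of growth and lower numbers for stronger inhibition of growth:
compound 1 `Cc1ccc(CNc2nc(Nc3ccc(N4CCN(C)CC4)cn3)ncc2Cl)cc1`: 12700 nM
compound 2 `CN1CCN(c2ccc(Nc3ncc(Cl)c(NCc4ccco4)n3)nc2)CC1`: > 100000 nM (a limit of the assay, not a number)

Compound 2 is known only as a limit, (the limit of > 100000 nM in this assay, at which 1 of the 2 values shown sits). Compound 3 `Cc1ccc(Nc2nc(Nc3ccc(N4CCN(C)CC4)cn3)ncc2Cl)cc1` is yet to be measured in this assay. It carries 4-methylphenyl in place of (furan-2-yl)methyl on a nitrogen on an aromatic ring.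

Among the measured compounds shown here, one measured step bears on this change: an at least 7.8-fold higher number from compound 1 to compound 2 (0.89 log units; beyond the scatter). That step, beyond the scatter, put furan-2-yl in place of 4-methylphenyl on a saturated chain carbon bound to a nitrogen on an aromatic ring. For the measured compounds named here, compound 3 regains 4-methylphenyl, but no measured step covers that group standing on the nitrogen itself, so the size of the change remains uncertain. A lower number, beyond the scatter, is therefore expected, and the expected step is an at least 12-fold lower number from compound 2 to compound 3 (1.09 log units; beyond the scatter). For compound 3 the estimated value is 8000 nM, with an expected range of 1500 nM to 40000 nM.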

Compound 3, concentration for 50% growth inhibition: 30900 nM
Compound 3: the middle estimate sits 3.9-fold (0.59 log units) below what was measured; measured number inside the range.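

In this assay, setting 4-methylphenyl on the nitrogen on an aromatic ring in place of 4-methylbenzyl gives a 2.4-fold higher number from compound 1 to compound 3 (0.39 log units; beyond the scatter), so the saturated chain carbon makes a modest difference here even when the 4-methylphenyl group is kept. The change from (furan-2-yl)methyl to 4-methylphenyl gives an at least 3.2-fold lower number from compound 2 to compound 3 (0.51 log units; beyond the scatter), so this nitrogen tolerates the loss of the chain carbon better than the exchange of 4-methylphenyl for furan-2-yl on that carbon. The true size of that change stays unknown, since compound 2 stands only as a limit of the assay: the limit of > 100000 nM in this assay, at which 1 of the 3 values shown sits.

What the compounds shown leave open is whether the trend with chain length continues, as a 2-phenylethyl group on this nitrogen would show. They also leave open whether an unsubstituted benzyl group would behave like 4-methylbenzyl, so the part played by the methyl group remains unsettled.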